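Hydrogen in place of methoxy: compound 1 to compound 3

The source may report more compounds than this note shows. Statements on the series, on what has been measured and on what is new or still open speak of the compounds shown alone.

For the measured compounds named here, compound 1 `COc1ccc(Cl)c(-c2nnc3sc(Cc4c[nH]c5ccc(OC)cc45)nn23)c1` gives 14.4% in a functional assay on the whole organism (strain Wistar Albino) for inhibition, with Rattus norvegicus as the target, read by paw edema, with a stated time of 2 h, at a dose of 20 mg/kg (a lower number here means less inhibition, a higher number more inhibition at the dose given (going by the name of the read-out)), the lower of the two numbers measured so far, though its only neighbour lies within the scatter. That neighbour, compound 2 `COc1ccc(Cl)c(-c2nnc3sc(Cc4c(C)[nH]c5ccc(OC)cc45)nn23)c1`, gives 20% in this assay; the step of a number 5.6 percentage points higher from compound 1 to compound 2 (within the scatter) is within the scatter, so the two values cannot be told apart.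

Compound 3 `COc1ccc(Cl)c(-c2nnc3sc(Cc4c[nH]c5ccccc45)nn23)c1` has yet to be measured in this assay. It differs from compound 1 by hydrogen in place of methoxy on an aromatic carbon, on an aromatic carbon of the six-membered aromatic ring of carbon only that forms part of the fused system of two rings. Going by the values given here, the single measured step, methyl in place of hydrogen on an aromatic carbon, concerns a different change at a different place and stayed within the scatter; it does not bear on this one. Among the compounds with values here, no measured pair shows what removing a methoxy does here, so nothing in the data points to a step beyond the scatter in either direction. The step expected is therefore a number 0.4 percentage points lower from compound 1 to compound 3 (within the scatter). Compound 3 is estimated at 14%, with a range from 4% to 26%.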

Compound 3, a percentage reported as inhibition, in the whole organism at one dose (the size of the read-out at that dose, not a potency): 16.5%
Estimate against measurement, compound 3: 2.5 percentage points below; measured number inside the range.
By their numbers in this assay, from the lowest: compounds 1, 3 and 2 (each within the scatter of the next).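

In this assay, for the compounds shown here, the first measured pair at this position shows that the methoxy on the aromatic carbon of the six-membered aromatic ring can give way to hydrogen with no step that stands out from the scatter (a number 2.1 percentage points higher from compound 1 to compound 3 (within the scatter)). For compound 1 and compound 3, then, the percentage read at this dose and time gives no sign that the methoxy is needed, and the read-out for this pair stays at the low level of compound 1, so this position has not yet shown any influence on the number. No measured property of these compounds is at hand to account for this flat result.

Going by these compounds, it remains open whether a different group at this place, such as an amine, a carboxylic acid or a longer alkoxy chain, would give a step beyond the scatter in either direction. A single pair with a single substituent swap also cannot show whether the same flat result would hold on a core carrying other groups, or at another dose or time.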